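A few compounds are considered here, and "the series" means these few. Any claim that something is new, unique, unknown or untested is made for them only; others in the source may bear on it.

Measured compounds:
- Compound 1 `CCOC(=O)c1cc(-c2ccc(Oc3ccccc3)cc2)nn1Cc1cccc(NC(=O)CCl)c1`: 400 nM
- Compound 2 `C/C=C/C(=O)Nc1cccc(Cn2nc(-c3ccc(Oc4ccccc4)cc3)cc2CO)c1`: 22600 nM
- Compound 3 `C=CC(=O)Nc1cccc(Cn2nc(-c3ccc(Oc4ccccc4)cc3)cc2CO)c1`: 5200 nM

In a functional assay on JeKo-1 cells (Homo sapiens) for inhibition, read by luminescence and CellTiter-Glo, with a stated time of 72 h (on this read-out lower numbers stand for stronger inhibition and higher numbers for weaker inhibition), compound 3 holds the second highest of the three numbers. Among the measured compounds shown here, its nearest neighbour is compound 2, and the step of a 4.3-fold lower number from compound 2 to compound 3 (0.64 log units; beyond the scatter) is the only single-point change among the measured pairs. Compound 1 differs from compound 3 in more than one place, so the two values can only be set side by side: compound 1 gives the lowest number of the three.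

Compound 4 `O=C(CCl)Nc1cccc(Cn2nc(-c3ccc(Oc4ccccc4)cc3)cc2CO)c1` is not yet measured. It differs from compound 3 by chloromethyl in place of vinyl on a carbonyl carbon. For the measured compounds named here, no measured step bears directly on this change. Going by the values given here, the one measured step, from compound 2 to compound 3, shows that a change at the same carbonyl carbon can move this assay by a modest amount beyond the scatter. Compound 1, which carries the same (chloromethyl)carbonyl group on a different core, gives 400 nM, the lowest value of the set. On that basis compound 4 is expected to give a lower number than compound 3, a step of roughly a 4.3-fold lower number from compound 3 to compound 4 (0.64 log units; beyond the scatter). The estimate for compound 4 in this assay is 1200 nM, with a range from 300 nM to 5000 nM.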

Compound 4, half-maximal inhibitory concentration: 400 nM
Estimate against measurement, compound 4: 3.0-fold (0.48 log units) above; measured number inside the range.
By their numbers in this assay, from the lowest: compounds 1 and 4 (each within the scatter of the next); then compound 3; then compound 2.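

Among the compounds shown here, the carbonyl carbon proves more sensitive than the one earlier step could show: in this assay, the large step of a 13-fold lower number from compound 3 to compound 4 (1.11 log units; beyond the scatter) exceeds the modest change between the two alkenyl groups, and a 57-fold lower number from compound 2 to compound 4 (1.75 log units; beyond the scatter) spans the widest range seen at this position. For the compounds shown here, with the (chloromethyl)carbonyl group held constant, exchanging ethoxycarbonyl for hydroxymethyl on the aromatic carbon gives no change at the digits printed from compound 1 to compound 4 (within the scatter), so this site, unreadable until now, shows no effect in this pair. Nothing available explains why chloromethyl gives the lower number here.

As far as these compounds go, it remains open whether the chlorine itself matters, which a plain methyl or a bromomethyl group on the same carbonyl carbon would test. From the compounds shown here alone, it is also open whether the aromatic carbon would accept a carboxylic acid or an amine as readily as it accepts hydroxymethyl and ethoxycarbonyl.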